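The source may hold more compounds than are shown below. What is called first, only, known or untested is meant among the compounds shown, and "the series" means these compounds.

Three urea-type compounds that share one core were tested in a functional assay on HT-29 cells (Homo sapiens) for antiproliferative activity, read by MTT assay, with a stated time of 72 h; a higher number here means a weaker inhibitor, a lower number a stronger inhibitor. Compound 1 `CN(C)CCn1cnnc1-c1cc(Oc2ccc(NC(=O)Nc3cccc(C(F)(F)F)c3)cc2F)ccn1` gives 1470 nM. Compound 2 `CN(C)CCn1cnnc1-c1cc(Oc2ccc(NC(=O)Nc3ccccc3C(F)(F)F)cc2F)ccn1`, which carries 2-(trifluoromethyl)phenyl in place of 3-(trifluoromethyl)phenyl on an amide-type nitrogen, gives 5860 nM; that change made a 4.0-fold higher number from compound 1 to compound 2 (0.60 log units; beyond the scatter). Compound 3 `CN(C)CCCn1cnnc1-c1cc(Oc2ccc(NC(=O)Nc3cccc(C(F)(F)F)c3)cc2F)ccn1` has a core that differs from that of compound 1 by (dimethylamino)methyl in place of dimethylamino on a saturated chain carbon, two bonds along the chain from an aromatic nitrogen; in this assay compound 3 gives 980 nM, and that change made a 1.5-fold lower number from compound 1 to compound 3 (0.18 log units; within the scatter), so the two cores behave alike as far as the data show.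

Compound 4 `CN(C)CCCn1cnnc1-c1cc(Oc2ccc(NC(=O)Nc3ccccc3C(F)(F)F)cc2F)ccn1` has not yet been measured in this assay. It stands to compound 3 exactly as compound 2 stands to compound 1: the difference is 2-(trifluoromethyl)phenyl in place of 3-(trifluoromethyl)phenyl on an amide-type nitrogen, the same change at the same place as before. Because the core change gave only a 1.5-fold lower number from compound 1 to compound 3 (0.18 log units; within the scatter), the change is expected to act on compound 3 much as it did on compound 1, so a step of about a 4.0-fold higher number from compound 3 to compound 4 (0.60 log units; beyond the scatter) is estimated, matching a 4.0-fold higher number from compound 1 to compound 2 (0.60 log units; beyond the scatter). On that basis compound 4 is expected to give roughly 3900 nM in this assay, most likely between 2000 nM and 8000 nM, which rests on one prior pair only.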

Compound 4, half-maximal inhibitory concentration: 3130 nM
For compound 4 the middle estimate is 1.2-fold (0.10 log units) above the measured one, and the stated range covers the measured number.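

On the core of compound 3, putting 2-(trifluoromethyl)phenyl in place of 3-(trifluoromethyl)phenyl on the amide-type nitrogen gives a 3.2-fold higher number from compound 3 to compound 4 (0.50 log units; beyond the scatter), so this change repeats on a second core at much the same size: the same change on two cores in this assay, a 4.0-fold higher number (0.60 log units; beyond the scatter) from compound 1 to compound 2 and a 3.2-fold higher number (0.50 log units; beyond the scatter) from compound 3 to compound 4, 1.2-fold (0.10 log units) apart, within the scatter of two such steps. The change in the chain, with (dimethylamino)methyl in place of dimethylamino, gives a 1.9-fold lower number from compound 2 to compound 4 (0.27 log units; within the scatter) when read on the 2-(trifluoromethyl)phenyl compounds, and it stays within the scatter on both pairs: the same change on two cores in this assay, a 1.5-fold lower number (0.18 log units; within the scatter) from compound 1 to compound 3 and a 1.9-fold lower number (0.27 log units; within the scatter) from compound 2 to compound 4, 1.2-fold (0.10 log units) apart, within the scatter of two such steps. Across these four compounds, then, each change seems to act without regard to the other, but this rests on just two closely related cores in this assay and does not show that the step would carry over to a core that differs more.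

The compounds shown leave open whether the same step would appear with a still longer chain, or with a morpholine in place of the dimethylamino group. They also leave open what a nitrile in place of the trifluoromethyl group would do.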